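A few compounds are considered here, and "the series" means these few. Any claim that something is new, unique, unknown or untested is made for them only; others in the source may bear on it.

Measured compounds:
- compound 1, `O=C(/C=C\c1cccc([N+](=O)[O-])c1)N1N=C(c2ccncc2)OC1c1c[nH]c2ccccc12`: > 30 ug/mL
- compound 2, `O=C(/C=C\c1ccccc1Cl)N1N=C(c2ccncc2)OC1c1c[nH]c2ccccc12`: > 30 ug/mL

In an ADME assay on A549 cells (Homo sapiens) for cytotoxicity, read by MTT assay, with a stated time of 48 h (on this read-out higher numbers stand for weaker inhibition of growth and lower numbers for stronger inhibition of growth), compound 1 gives > 30 ug/mL, and this is a limit of the assay rather than a number. Compound 2 gives > 30 ug/mL in this assay, which is again a limit of the assay. The step from compound 1 to compound 2 therefore reads a step that the two limits leave unreadable from compound 1 to compound 2, and this is all that is known of the pair; both values sit at the limit of > 30 ug/mL in this assay, at which 2 of the 2 values shown sit. Compound 2 thus stands only at a limit, with no number of its own.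

Compound 3, `O=C(/C=C\c1ccc(Cl)cc1)N1N=C(c2ccncc2)OC1c1c[nH]c2ccccc12`, has not yet been measured in this assay. It differs from compound 2 in one place: 4-chlorophenyl in place of 2-chlorophenyl on a double-bonded chain carbon bound to a double-bonded chain carbon. Within the data shown here, the only measured step, the one from compound 1 to compound 2, is unreadable in size, so it gives no direction for this change. The expectation for the step from compound 2 to compound 3 is therefore a step that the limit leaves unreadable from compound 2 to compound 3, with no movement beyond the scatter expected. Compound 3 is estimated at 45 ug/mL, within a range from 20 ug/mL to 120 ug/mL, most likely reported again as a limit.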

Compound 3, concentration for 50% growth inhibition: > 30 ug/mL
Compound 3 ended at the assay's limit; the forecaster's own chance of this, stated with the estimate: 80%; the middle value lies beyond the limit too.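

In this assay compound 3 gives > 30 ug/mL, again a limit of the assay. The steps to compound 3 from compound 1 and from compound 2 therefore cannot be read: the limit of > 30 ug/mL in this assay, at which 3 of the 3 values shown sit.

The compounds shown leave open whether 3-nitrophenyl, 2-chlorophenyl and 4-chlorophenyl differ at all in their effect on growth inhibition.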